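Acyl hydrazide in place of the thiazolyl amide

The source may report more compounds than this note shows. Statements on the series, on what has been measured and on what is new or still open speak of the compounds shown alone.

Compound 3 `COc1ccc2nc(C)cc(OCC(=O)Nc3nc(C)c(C)s3)c2c1` holds the lowest number of the three measured in a physicochemical assay for lipophilicity, read by HPLC, in phosphate buffer, measured as chromatographic lipophilicity, at pH 7.4 (a lower number here means a more polar compound, a higher number a more lipophilic compound), giving 4.24; its nearest neighbour is compound 1 `COc1ccc2nc(C)cc(OCC(=O)Nc3ccccc3)c2c1`, which in this assay gives 4.28, while compound 2 `COc1ccc2nc(C)cc(OCC(=O)Nc3cc(F)cc(F)c3)c2c1` gives 5.13. For the measured compounds named here, the steps so far all concern the group on the amide-type nitrogen: a number 0.85 log units higher from compound 1 to compound 2 (beyond the scatter), a number 0.04 log units lower from compound 1 to compound 3 (within the scatter) and a number 0.89 log units lower from compound 2 to compound 3 (beyond the scatter). All three are exchanges of one aromatic ring for another at that position, and only the fluorinated ring moved the number beyond the scatter.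

Compound 4 `COc1ccc2nc(C)cc(OCC(=O)NNC(=O)c3ccncc3)c2c1` is the next member, not yet measured. The change from compound 3 is ((pyridin-4-yl)carbonyl)amino in place of 4,5-dimethyl-1,3-thiazol-2-yl on an amide-type nitrogen. Going by the values given here, this is not an aryl-for-aryl swap like the measured steps; the group entering carries a carbonyl and a hydrogen-bond donor that none of the measured steps introduced, so those steps set no direct precedent. A step larger than a number 0.89 log units lower from compound 2 to compound 3 (beyond the scatter), and downward, is expected in this assay. Compound 4 is expected to give about 2.6, with a plausible range from 1.9 to 3.3. The estimated step of a number 1.64 log units lower from compound 3 to compound 4 (beyond the scatter) would carry compound 4 well below every measured member.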

Compound 4, distribution coefficient: 1.48
Compound 4: the middle estimate sits 1.12 log units above what was measured; measured number below the stated range.
By their numbers in this assay, from the lowest: compound 4; then compounds 3 and 1 (each within the scatter of the next); then compound 2.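

In this assay the group on the amide-type nitrogen can shift the number much further than the exchanges of one aromatic ring for another indicated, with a number 2.76 log units lower from compound 3 to compound 4 (beyond the scatter) and a number 2.80 log units lower from compound 1 to compound 4 (beyond the scatter) and a number 3.65 log units lower from compound 2 to compound 4 (beyond the scatter) all large and beyond the scatter. Compound 4 therefore holds the lowest number of the four, and the entering ((pyridin-4-yl)carbonyl)amino brings a carbonyl and a hydrogen-bond donor along with a different aromatic ring, so this single exchange changes several features at once. No measurement is available that explains the size of this drop.

The compounds shown do not separate the contribution of the pyridin-4-yl ring from that of the carbonyl and amino link, a question that a phenylcarbonylamino group on the same nitrogen would address directly. As far as these compounds go, it also remains open whether a pyridin-3-yl ring in the same group, or a methyl group on the amino nitrogen in place of its hydrogen, would leave the number near that of compound 4 or move it away.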